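Moving the trifluoromethyl group on the pendant phenyl ring

The source may hold more compounds than are shown below. What is called first, only, known or untested is meant among the compounds shown, and "the series" means these compounds.

Measured compounds:
Compound 1, `Oc1ccc(-c2cc(-c3ccccc3F)cc(-c3ccccc3O)n2)cc1`: in a functional assay on HCT-15 cells (Homo sapiens) for inhibition (on this read-out lower numbers stand for stronger inhibition and higher numbers for weaker inhibition), compound 1 gives > 50000 nM, a limit of the assay rather than a number.
Compound 2, `Oc1ccc(-c2cc(-c3cccc(F)c3)cc(-c3ccccc3O)n2)cc1`: in this assay compound 2 gives > 50000 nM, again a limit of the assay.
Compound 3, `Oc1ccc(-c2cc(-c3ccccc3C(F)(F)F)cc(-c3ccccc3O)n2)cc1`: in this assay compound 3 gives 8990 nM.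

Compound 3 is thus the only one of the three with a number at all; the other two sit at the limit of > 50000 nM in this assay, at which 2 of the 3 values shown sit. The steps of an at least 5.5-fold lower number from compound 1 to compound 3 (0.74 log units; beyond the scatter) and an at least 5.5-fold lower number from compound 2 to compound 3 (0.74 log units; beyond the scatter) are both read against that limit, so their true size is open-ended.

Compound 4, `Oc1ccc(-c2cc(-c3cccc(C(F)(F)F)c3)cc(-c3ccccc3O)n2)cc1`, has not yet been measured. Its change from compound 3 is 3-(trifluoromethyl)phenyl in place of 2-(trifluoromethyl)phenyl on an aromatic carbon. The nearest measured analogy is the shift of the fluoro substituent, a step that the two limits leave unreadable from compound 1 to compound 2, which both limits leave unreadable. No measured step therefore fixes the size or direction of moving the trifluoromethyl group; the one number shown, for compound 3, is the only anchor.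

For compound 4 the expectation is a small loss or no change beyond the scatter, a 1.7-fold higher number from compound 3 to compound 4 (0.22 log units; within the scatter), with a fair chance the assay returns only a limit. The estimate for compound 4 is 15000 nM, between 4000 nM and 50000 nM.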

Compound 4, half-maximal inhibitory concentration: > 50000 nM
Compound 4: a limit, no number; the forecaster's own chance of this, stated with the estimate: 35%; at least 3.3-fold (0.52 log units) between middle value and limit.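

Moving the group from 2-(trifluoromethyl)phenyl to 3-(trifluoromethyl)phenyl, on the aromatic carbon opposite the ring nitrogen, gives an at least 5.5-fold higher number from compound 3 to compound 4 (0.74 log units; beyond the scatter); in this assay, the presence of a trifluoromethyl group on the pendant phenyl ring is therefore not enough to give a measurable value, and where it sits on that ring matters. Compound 4 gives > 50000 nM, which is a limit of the assay and not a number, so the step has a floor but no known upper end. Compound 3, with its 2-(trifluoromethyl)phenyl group, remains the only compound here with a number, and the other three share one limit: the limit of > 50000 nM in this assay, at which 3 of the 4 values shown sit.

The steps from compound 1 and from compound 2 to compound 4 join two limits and cannot be read, so 2-fluorophenyl, 3-fluorophenyl and 3-(trifluoromethyl)phenyl cannot be ranked against one another. Also open, as far as these compounds go, is whether the value of compound 3 depends on trifluoromethyl itself, or whether a methoxy group, an amine or a carboxylic acid in its place would also give a number in this assay.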